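The source may hold more compounds than are shown below. What is called first, only, known or untested is meant among the compounds shown, and "the series" means these compounds.

Compound 3 `COc1ccc(CNC(=O)/C(C#N)=C/c2cc(Br)co2)cc1` gives the highest number of the three measured in a functional assay on DU-145 cells (Homo sapiens) for inhibition, read by MTT assay, with a stated time of 72 h (a lower number here means a stronger inhibitor of growth, a higher number a weaker inhibitor of growth), at 61000 nM. In this assay compound 1 `COc1ccc(CNC(=O)/C(C#N)=C/c2ccco2)cc1` gives 29000 nM and compound 2 `COc1ccc(CNC(=O)/C(C#N)=C/c2ccc(Cl)o2)cc1` gives 12000 nM. The measured steps were a 2.1-fold higher number from compound 1 to compound 3 (0.32 log units; beyond the scatter) and a 5.1-fold higher number from compound 2 to compound 3 (0.71 log units; beyond the scatter).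

Compound 4 `COc1ccc(CNC(=O)/C(C#N)=C/c2ccc(Cl)cc2)cc1` differs from compound 3 by 4-chlorophenyl in place of 4-bromofuran-2-yl on a double-bonded chain carbon bound to a double-bonded chain carbon. Within the data shown here, no measured step exchanges the furan ring for a benzene ring, so that part of the change is untested. Among the measured compounds shown here, the steps that bear on the halogen are a 2.4-fold lower number from compound 1 to compound 2 (0.38 log units; beyond the scatter) and a 5.1-fold higher number from compound 2 to compound 3 (0.71 log units; beyond the scatter), which favour a chloro over a bromo. In this assay the expected step is a 4.1-fold lower number from compound 3 to compound 4 (0.61 log units; beyond the scatter), because compound 2 gave 12000 nM. Compound 4 is therefore estimated at 15000 nM, within a range from 4000 nM to 60000 nM.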

Compound 4, concentration for 50% growth inhibition: 7000 nM
Beside the measured number, compound 4's estimate is 2.1-fold (0.33 log units) above it, within the range that was stated.
By their numbers in this assay, from the lowest: compounds 4 and 2 (each within the scatter of the next); then compound 1; then compound 3.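

In this assay the 4-chlorophenyl group on this double-bonded chain carbon gives a 4.1-fold lower number from compound 1 to compound 4 (0.62 log units; beyond the scatter) and an 8.7-fold lower number from compound 3 to compound 4 (0.94 log units; beyond the scatter) and so shows that a furan ring is not required at this place. Set against the 5-chlorofuran-2-yl group, the exchange gives a 1.7-fold lower number from compound 2 to compound 4 (0.23 log units; within the scatter) and leaves the two chloro-bearing groups indistinguishable. No evidence on the cause of these steps is at hand. Still open, on these data alone, is how a phenyl group without the chloro would compare, and whether an amine or a carboxylic acid in place of that chloro would keep these numbers.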